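N-Alkyl Variation on the Shared Core

The compounds below may be only part of what the source reports. "The series", "measured", "known", "first", "only" and "open" are said of these compounds alone.

Compound 1 `Cn1c(C2CC2)nc2ccc(-n3ccc(OCc4ccc(Cl)cc4)cc3=O)cc21` gives 21 nM in an assay on CHO cells for displacement of a labelled ligand from melanin-concentrating hormone receptor 1 (Rattus norvegicus), read by scintillation counting, with a stated time of 1 h (on this read-out lower numbers stand for stronger inhibition and higher numbers for weaker inhibition), the lowest of the two numbers recorded in the set. Compound 2 `Cn1c(C2CC2)nc2ccc(-n3ccc(OCc4ccc(F)cc4)cc3=O)cc21` gives 28 nM, and the step of a 1.3-fold higher number from compound 1 to compound 2 (0.12 log units; within the scatter). Compound 3 `Cn1c(CC(C)(C)C)nc2ccc(-n3ccc(OCc4ccc(F)cc4)cc3=O)cc21` gives > 1000 nM, which is a limit of the assay and not a number. The step of an at least 35-fold higher number from compound 2 to compound 3 (1.55 log units; beyond the scatter); the value of compound 3 sits at the limit of > 1000 nM in this assay, at which 1 of the 3 values shown sits.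

Compound 4 `CCn1c(C2CC2)nc2ccc(-n3ccc(OCc4ccc(Cl)cc4)cc3=O)cc21` differs from compound 1 by methyl in place of hydrogen on a saturated chain carbon bound to an aromatic nitrogen; cut one bond further out, the same difference reads methyl to ethyl. Neither measured step touches this position: the step from compound 1 to compound 2 concerns the halogen on the benzyl ring, and the step from compound 2 to compound 3 concerns the group on the aromatic carbon of the core. No recorded change therefore bears directly on it, and a step within the scatter is expected, in no fixed direction. For compound 4 the estimated value is 30 nM, in the range 10 nM to 100 nM. The expected step is a 1.4-fold higher number from compound 1 to compound 4 (0.15 log units; within the scatter).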

Compound 4, half-maximal inhibitory concentration: 34 nM
For compound 4 the middle estimate is 1.1-fold (0.05 log units) below the measured one, within the range that was stated.
By their numbers in this assay, from the lowest: compounds 1, 2 and 4 (each within the scatter of the next). At a limit, above all of these: compound 3.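

Methyl to ethyl on the aromatic nitrogen of the shared core gives, in this assay, a 1.6-fold higher number from compound 1 to compound 4 (0.21 log units; within the scatter), the first reading of this position, since compounds 1, 2 and 3 all carry methyl there. With the chloro benzyl group and the cyclopropyl on the aromatic carbon kept in place, the added carbon leaves the two values within the scatter of each other, so this position accepts ethyl as well as methyl in this pair. Nothing on hand accounts for this result.

Still open, going by these compounds, is whether the same position accepts a longer chain such as propyl, a branched group such as isopropyl, or a chain ending in an amine or a carboxylic acid. Also open, on these data alone, is whether ethyl behaves the same way with the fluoro benzyl group of compound 2.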